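Hydroxy for amino on the core: expectation for compound 4

A few compounds are considered here, and "the series" means these few. Any claim that something is new, unique, unknown or untested is made for them only; others in the source may bear on it.

Measured compounds:
compound 1 `C=C1[C@@H](O)[C@H](n2cnc3c(N)nc(N)nc32)O[C@@H]1CO` gives > 200000 nM in a functional assay on L1210 cells (Mus musculus) for inhibition (on this read-out higher numbers stand for weaker inhibition and lower numbers for stronger inhibition), a limit of the assay.
compound 2 `C=C1[C@@H](O)[C@H](n2cnc3c(O)nc(N)nc32)O[C@@H]1CO` gives > 200000 nM in this assay, a limit of the assay.
compound 3 `C=C1[C@H](n2cnc3c(N)ncnc32)O[C@H](CO)[C@H]1O` gives 65000 nM in this assay.

Compound 1 to compound 2 carries the change (hydroxy in place of amino on an aromatic carbon); its step that the two limits leave unreadable from compound 1 to compound 2 cannot be sized, since the limit of > 200000 nM in this assay, at which 2 of the 3 values shown sit, covers both ends. How the core of compound 1 and the core of compound 3 differ is not broken down here.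

Compound 4 `C=C1[C@H](n2cnc3c(O)ncnc32)O[C@H](CO)[C@H]1O` is not yet measured in this assay. It carries hydroxy in place of amino on an aromatic carbon, the same kind of change as in compound 2, the place differing only in that compound 1 is also meta to an amino group (1 heavy atom). With only an unreadable step from compound 1 to compound 2 to rest on, the estimated step of a 2.3-fold higher number from compound 3 to compound 4 (0.36 log units; beyond the scatter) for compound 4 is weakly founded. Compound 4 is expected near 150000 nM, between 40000 nM and 500000 nM, with a real chance that this assay reports only a limit.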

Compound 4, half-maximal inhibitory concentration: 60000 nM
Compound 4: the middle estimate sits 2.5-fold (0.40 log units) above what was measured; measured number inside the range.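

In this assay, hydroxy in place of amino on the core of compound 3 gives a 1.1-fold lower number from compound 3 to compound 4 (0.03 log units; within the scatter), so the two compounds cannot be told apart on this read-out. The same change on the core of compound 1 cannot be read, because compound 1 and compound 2 both sit at a limit of the assay: the limit of > 200000 nM in this assay, at which 2 of the 4 values shown sit. This gives one readable instance of the change, and it does not show that the result on the core of compound 3 carries over to the core of compound 1.

Open, on these data alone, is whether a methoxy, chloro or methylamino group in the same place would separate from amino and hydroxy on the core of compound 3. Also open, as far as these compounds go, is how either group behaves on a core that gives stronger inhibition.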